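Removing the Indole Arm from Compound 3

The source may report more compounds than this note shows. Statements on the series, on what has been measured and on what is new or still open speak of the compounds shown alone.

Compound 1 `COc1ccc2nccc(C3CN(CC4CCCN(Cc5cc6ccccc6[nH]5)C4)C(=O)O3)c2c1`: < 50200 nM
Compound 2 `O=C1OC(c2ccnc3ccccc23)CN1C1CCN(Cc2cc3ccccc3[nH]2)CC1`: 1000 nM
Compound 3 `COc1ccc2nccc(C3CN(C4CCN(Cc5cc6ccccc6n5C)CC4)C(=O)O3)c2c1`: 3160 nM

All three compounds were tested in an in vitro functional assay on RBL cells for antagonist activity at C-C chemokine receptor type 8 (Homo sapiens), read by FLIPR and calcium flux; on this read-out lower numbers stand for stronger inhibition and higher numbers for weaker inhibition. For compound 1 the result < 50200 nM is a limit of the assay rather than a number. Compound 2 gives 1000 nM, while compound 3 gives 3160 nM; of these two numbers compound 3 holds the higher one, and the gap between them lies beyond the usual scatter of this assay.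

Compound 4 `COc1ccc2nccc(C3CN(C4CCN(C)CC4)C(=O)O3)c2c1` has not yet been measured. It differs from compound 3 in a single place: hydrogen in place of 1-methyl-1H-indol-2-yl on a saturated chain carbon bound to an amine nitrogen in a ring. Within the data shown here, no pair of measured compounds shares this change, so the step has to be judged from the structures alone. A large rise in the number, and thus much weaker inhibition, is expected, with a step of about a 9.5-fold higher number from compound 3 to compound 4 (0.98 log units; beyond the scatter). Compound 4 is therefore expected to give roughly 30000 nM, with a likely range from 8000 nM to 120000 nM, and a fair chance that only a limit is reported.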

Compound 4, half-maximal inhibitory concentration: < 50200 nM
Compound 4 ended at the assay's limit; the forecaster's own chance of this, stated with the estimate: 45%; the middle value does not contradict the limit.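

The result for compound 4 is a limit of the assay and not a number, so the step from compound 3 to compound 4 cannot be read: the limit of < 50200 nM in this assay, at which 2 of the 4 values shown sit.

The compounds shown leave open what size of change, if any, follows when hydrogen takes the place of 1-methyl-1H-indol-2-yl.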